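From One Branched Chain to Another: Compound 3 to Compound 4

The source may report more compounds than this note shows. Statements on the series, on what has been measured and on what is new or still open speak of the compounds shown alone.

Three compounds have been measured in a functional assay on MCF7 cells (Homo sapiens) for cytotoxicity, read by MTT assay, with a stated time of 3 days; a lower number here means a stronger inhibitor, a higher number a weaker inhibitor:

Compound 1, `C[C@H]1O[C@@H](n2cc(F)c(NC(=O)Oc3ccc(Cl)cc3)nc2=O)[C@H](O)[C@@H]1O`: 100 ug/mL
Compound 2, `C[C@H]1O[C@@H](n2cc(F)c(NC(=O)Oc3ccc([N+](=O)[O-])cc3)nc2=O)[C@H](O)[C@@H]1O`: 180 ug/mL
Compound 3, `CCC(C)COC(=O)Nc1nc(=O)n([C@@H]2O[C@H](C)[C@@H](O)[C@H]2O)cc1F`: 120 ug/mL

Compound 3 holds the second highest of the three numbers. Its nearest neighbour is compound 1 and its furthest is compound 2, yet both separations are small: a 1.2-fold higher number from compound 1 to compound 3 (0.08 log units; within the scatter) and a 1.5-fold lower number from compound 2 to compound 3 (0.18 log units; within the scatter), each within the scatter. Going by the values given here, the one step not involving compound 3, a 1.8-fold higher number from compound 1 to compound 2 (0.26 log units; within the scatter), is also within the scatter. So far, then, nothing has moved the number beyond the noise of the measurement.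

Compound 4, `CC(C)CCOC(=O)Nc1nc(=O)n([C@@H]2O[C@H](C)[C@@H](O)[C@H]2O)cc1F`, has not yet been measured. It differs from compound 3 as follows: isobutyl in place of sec-butyl on a saturated chain carbon bound to an oxygen next to a carbonyl group. The two steps that bear on this position are a 1.2-fold higher number from compound 1 to compound 3 (0.08 log units; within the scatter) and a 1.5-fold lower number from compound 2 to compound 3 (0.18 log units; within the scatter), both of which replaced an aromatic group by a branched chain and still stayed within the scatter. Rearranging one branched chain into another is a smaller alteration than either of those. Compound 4 is therefore expected to show no step beyond the scatter, no change at the digits printed from compound 3 to compound 4 (within the scatter). The estimate for compound 4 in this assay is 120 ug/mL, with a range from 60 ug/mL to 240 ug/mL.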

Compound 4, half-maximal inhibitory concentration: 120 ug/mL
The estimate for compound 4 equals the measured number at the digits printed, within the range that was stated.
By their numbers in this assay, from the lowest: compounds 1, 3, 4 and 2 (each within the scatter of the next).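

In this assay, isobutyl in place of sec-butyl on a saturated chain carbon bound to an oxygen next to a carbonyl group gives no change at the digits printed from compound 3 to compound 4 (within the scatter) and is the first step shown that keeps the same atoms and only joins them differently. The aromatic groups compare with the new chain much as they did with the old one, with a 1.5-fold lower number from compound 2 to compound 4 (0.18 log units; within the scatter) for isopentyl in place of 4-nitrophenyl and a 1.2-fold higher number from compound 1 to compound 4 (0.08 log units; within the scatter) for isopentyl in place of 4-chlorophenyl, so all four compounds now sit within the scatter of the next. Nothing available accounts for this lack of separation.

Going by these compounds, whether any group on this oxygen can move the number beyond the scatter remains open. A longer chain, or a chain ending in an amine or a carboxylic acid, would test that.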